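This account rests on a few compounds, and the source may have more. Where it says the series, first, only, none or still open, it means among the compounds named here.

Working notes on the sulfone series.

Compound 1 `Cn1c(=O)c(S(=O)(=O)c2ccc(Cl)cc2Cl)cc2cnc(Nc3ccc4[nH]ccc4c3)nc21` is one of three members measured in a functional assay on DU-145 cells (Homo sapiens) for inhibition, read by trypan blue exclusion, with a stated time of 72 h; on this read-out lower numbers stand for stronger inhibition and higher numbers for weaker inhibition. In this assay compound 1 gives 1000 nM, and compound 2 `Cn1c(=O)c(S(=O)(=O)c2ccccc2)cc2cnc(Nc3cnc4[nH]ccc4c3)nc21` gives 1000 nM; these two numbers sit together, within the scatter of each other, and are the two lowest of the set. Compound 3 `COc1ccc(Nc2ncc3cc(S(=O)(=O)c4ccc(Cl)cc4)c(=O)n(C)c3n2)cc1` gives 30000 nM in this assay, a clearly higher number than compound 1, well beyond the scatter; compound 3 differs from compound 1 at the amine as well as at the sulfonyl group, so the gap cannot be tied to one place.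

Compound 4 `Cn1c(=O)c(S(=O)(=O)c2ccc(F)cc2)cc2cnc(Nc3ccc4[nH]ccc4c3)nc21` keeps the core and the amine of compound 1 and changes only the group on the sulfonyl sulfur: 4-fluorophenyl in place of 2,4-dichlorophenyl on a sulfonyl sulfur. Going by the values given here, no measured pair in the set isolates this exchange. Compound 2, with an unsubstituted phenyl on the sulfonyl, stands level with compound 1, which suggests that the substitution pattern on this ring is tolerated; compound 3 cautions against over-reading that. The expected step from compound 1 to compound 4 in this assay is a 2.0-fold higher number from compound 1 to compound 4 (0.30 log units; within the scatter), a small move toward a higher number that may not exceed the scatter. For compound 4 the estimate in this assay is 2000 nM, ranging from 700 nM to 6000 nM.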

Compound 4, half-maximal inhibitory concentration: 300 nM
For compound 4 the middle estimate is 6.7-fold (0.82 log units) above the measured one; the measured number lies below the stated range.
By their numbers in this assay, from the lowest: compound 4; then compounds 1 and 2 (each within the scatter of the next); then compound 3.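

In this assay the group on the sulfonyl sulfur now reads on its own: with the core and the amine held fixed, 4-fluorophenyl in place of 2,4-dichlorophenyl gives a 3.3-fold lower number from compound 1 to compound 4 (0.52 log units; beyond the scatter). Going by these compounds alone, this is the first pair that differs in one place, so this position can be separated from the amine, and the step shows that the read-out responds to the change here, modestly but beyond the scatter. Nothing measured on these compounds accounts for the step.

Within the data shown here, the single pair leaves open how much of the step goes with the two chlorine atoms leaving and how much with the fluorine entering. It also leaves open how a 4-methoxyphenyl or a cyclohexyl group on the sulfonyl sulfur would read with this core and amine, and whether the step carries over to another amine.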